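The source may hold more compounds than are shown below. What is called first, only, known or untested is meant among the compounds shown, and "the series" means these compounds.

Three hydrazones sharing one core have been examined in an ADME assay on MT4 cells (Homo sapiens) for cytotoxicity, read by MTT assay, with a stated time of 4 days; on this read-out higher numbers stand for lower toxicity in this test and lower numbers for higher toxicity in this test. Compound 1 `COc1cc(/C=N/NC(=O)COc2cccc3ccccc23)cc(OC)c1OC` gives 13.4 ug/mL, compound 3 `O=C(COc1cccc2ccccc12)N/N=C/c1cccc([N+](=O)[O-])c1` gives 12.1 ug/mL, and compound 2 `O=C(COc1cccc2ccccc12)N/N=C/c1ccc(O)cc1` gives 26.5 ug/mL. Compound 2 thus holds the highest of the three numbers shown, but its gap to compound 1 lies within the usual scatter, and only its gap to compound 3 lies beyond it.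

Compound 4 `O=C(COc1cccc2ccccc12)N/N=C/c1ccccc1Br` has not yet been tested in this assay. It differs from compound 2 in one place: 2-bromophenyl in place of 4-hydroxyphenyl on a carbon with a double bond to nitrogen.

Among the measured compounds shown here, no measured pair in this set shows a single change of this kind, so any expectation rests on the spread of the three values. Both compound 1 and compound 3 lack the hydroxyl of compound 2 and sit somewhat lower, so a modest decrease is expected, with the step of a 1.8-fold lower number from compound 2 to compound 4 (0.25 log units; within the scatter) thought to lie near the edge of the scatter. For compound 4 in this assay the estimate is 15 ug/mL, with a likely range from 6 ug/mL to 35 ug/mL.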

Compound 4, half-maximal cytotoxic concentration: 11.4 ug/mL
For compound 4 the middle estimate is 1.3-fold (0.12 log units) above the measured one; the measured number falls inside the stated range.
By their numbers in this assay, from the lowest: compounds 4, 3, 1 and 2 (each within the scatter of the next, the first and the last beyond it).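

In this assay, among the compounds shown here, the exchange of 4-hydroxyphenyl for 2-bromophenyl on a carbon with a double bond to nitrogen gives a 2.3-fold lower number from compound 2 to compound 4 (0.37 log units; beyond the scatter), the first single change in this set to be read, and it shows that the number can move beyond the scatter through this position alone. The step replaces a group with 1 hydrogen-bond donor and 1 hydrogen-bond acceptor by one with 0 of each, while the heavy-atom count stays at 7, but one step cannot separate losing the hydroxyl from gaining the bromine. Nothing in the data accounts for the step.

On these data alone, what a plain phenyl would give at this place remains open, and that value would help separate those two parts of the change. Also open, as far as these compounds go, is whether an amine or a carboxylic acid on this ring would behave as the hydroxyl does.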